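The source may hold more compounds than are shown below. What is called first, only, known or untested is meant among the compounds shown, and "the series" means these compounds.

Measured so far in a functional assay on SK-MEL-28 cells (Homo sapiens) for cytotoxicity, read by MTT assay; a lower number here means a stronger inhibitor, a higher number a weaker inhibitor:
compound 1 `O=S(=O)(NCCNc1nccc(-c2c(-c3cccc(F)c3)nc3sccn23)n1)c1ccc(Br)cc1`: 13500 nM
compound 2 `COc1ccc(S(=O)(=O)NCCCNc2nccc(-c3c(-c4cccc(F)c4)nc4sccn34)n2)cc1`: 8980 nM
compound 3 `O=S(=O)(NCCCNc1nccc(-c2c(-c3cccc(F)c3)nc3sccn23)n1)c1ccc(C(F)(F)F)cc1`: 11700 nM

Compound 1 gives the highest of the three numbers, but its gaps to compound 3 and to compound 2 are both within the scatter, so no order among the three is claimed. The change to compound 4 `Cc1ccc(S(=O)(=O)NCCNc2nccc(-c3c(-c4cccc(F)c4)nc4sccn34)n2)cc1` is methyl in place of bromo on an aromatic carbon. For the measured compounds named here, the one measured step that bears on this position is a 1.3-fold higher number from compound 2 to compound 3 (0.11 log units; within the scatter), a swap of one group for another on an aromatic carbon of the same phenyl of the sulfonyl group, although compound 2 and compound 3 carry a different linker from compound 1. On that precedent the expected step in this assay is a 1.1-fold lower number from compound 1 to compound 4 (0.05 log units; within the scatter), that is, none beyond the scatter. Compound 4 is therefore estimated at 12000 nM, range 6000 nM to 25000 nM.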

Compound 4, half-maximal inhibitory concentration: > 20000 nM
Compound 4 ended at the assay's limit (the forecaster's own chance of this, stated with the estimate: 10%); middle value at least 1.6-fold (0.22 log units) from the limit.
By their numbers in this assay, from the lowest: compounds 2, 3 and 1 (each within the scatter of the next). At a limit, above all of these: compound 4.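

In this assay compound 4 gives > 20000 nM as a limit of the assay and not a number. Methyl in place of bromo is the first change at this position read on the linker of compound 1, and it gives an at least 1.4-fold higher number from compound 1 to compound 4 (0.17 log units; that floor lies within the scatter) and that floor does not separate the pair. How far the step runs past that floor cannot be read: the limit of > 20000 nM in this assay, at which 1 of the 4 values shown sits.

From the compounds shown here alone, whether an amine or a carboxylic acid on this aromatic carbon would give a readable number stays open. So does how methyl and bromo compare on the linker of compound 2 and compound 3.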